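Swapping the phenyl for a dichlorophenyl on the core

This account rests on a few compounds, and the source may have more. Where it says the series, first, only, none or still open, it means among the compounds named here.

Compounds measured so far:
compound 1, `COc1cc(/C=C/C(=O)C2=C(/C=C/c3ccc(O)c(OC)c3)NC(=O)NC2c2ccccc2)ccc1O`, 26.4%
compound 2, `COc1cc(/C=C/C(=O)C2=C(/C=C/c3ccc(O)c(OC)c3)NC(=O)NC2c2ccc(C)cc2)ccc1O`, 29.9%
compound 3, `COc1cc(/C=C/C(=O)C2=C(/C=C/c3ccc(O)c(OC)c3)NC(=O)NC2c2ccc(N(C)C)cc2)ccc1O`, 37.6%

All three share one core and differ only in the group attached to the saturated ring carbon. In a functional assay, with a stated time of 20 min, tested at 10 uM (on this read-out higher numbers stand for a stronger effect at the one concentration tested and lower numbers for a weaker effect), compound 1 gives 26.4%, the lowest of the three numbers. The step of a number 3.5 percentage points higher from compound 1 to compound 2 (within the scatter) lies within the scatter, so no order between compound 1 and compound 2 can be read from it. The step of a number 11.2 percentage points higher from compound 1 to compound 3 (beyond the scatter) is beyond the scatter and modest, and a number 7.7 percentage points higher from compound 2 to compound 3 (within the scatter) is again within the scatter.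

Compound 4, `COc1cc(/C=C/C(=O)C2=C(/C=C/c3ccc(O)c(OC)c3)NC(=O)NC2c2c(Cl)cccc2Cl)ccc1O`, is not yet measured. Compared with compound 1 it carries the change (2,6-dichlorophenyl in place of phenyl on a saturated ring carbon). Among the compounds with values here, none of the measured steps places chlorine anywhere, and none changes the ring at two carbons at once, so the measured steps bear on this change only loosely: they show that small changes on this aromatic ring have so far shifted this assay by little or a modest amount. On that basis the step of a number 3.6 percentage points higher from compound 1 to compound 4 (within the scatter) is expected to stay within the scatter. Compound 4 is therefore estimated at 30%, with a range from 17% to 43%.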

Compound 4, a percentage reported as activity, at one concentration (the size of the read-out at that concentration, not a potency): 19.2%
For compound 4 the middle estimate is 10.8 percentage points above the measured one, within the range that was stated.
By their numbers in this assay, from the lowest: compounds 4, 1, 2 and 3 (each within the scatter of the next, the first and the last beyond it).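

In this assay, putting 2,6-dichlorophenyl in place of phenyl on the saturated ring carbon gives a number 7.2 percentage points lower from compound 1 to compound 4 (within the scatter), so the two chlorines leave no readable difference from the plain phenyl ring. The comparisons with the other two rings say more: 2,6-dichlorophenyl in place of 4-methylphenyl gives a number 10.7 percentage points lower from compound 2 to compound 4 (beyond the scatter), and in place of 4-(dimethylamino)phenyl it gives a number 18.4 percentage points lower from compound 3 to compound 4 (beyond the scatter), which shows that the group on this carbon can shift the read-out over a wider span than the first three compounds revealed, though both steps are still modest. Nothing available explains these differences.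

The compounds shown leave open whether a single chlorine, as in a 4-chlorophenyl group, would read like compound 4 or like compound 2, and whether a methoxy group or a carboxylic acid on this aromatic ring would extend the span in either direction. They also leave open what happens when the aromatic ring on this carbon gives way to a cyclohexyl group or a short alkyl chain.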